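Extending the benzamide linker by an ethenyl unit

The compounds below may be only part of what the source reports. "The series", "measured", "known", "first", "only" and "open" are said of these compounds alone.

Compound 3 `Nc1ccccc1NC(=O)c1ccc(Cn2cnc3c(Nc4cccc(OC(F)(F)F)c4)nc(Cl)nc32)cc1` stands highest among the three measured compounds in a functional assay on NCI-H460 cells (Homo sapiens) for antiproliferative activity, read by CCK-8 assay, with a stated time of 72 h, tested at 2 uM (on this read-out lower numbers stand for a weaker effect and higher numbers for a stronger effect at the one concentration tested), giving 47.7%, while compound 1 `Nc1ccccc1NC(=O)/C=C/c1ccc(Cn2cnc3c(Nc4cccc(Cl)c4)nc(Cl)nc32)cc1` gives 7.11% and compound 2 `Nc1ccccc1NC(=O)/C=C/c1ccc(Cn2cnc3c(NC4CCCCC4)nc(Cl)nc32)cc1` gives 8.09%. Going by the values given here, the only measured step, a number 1 percentage points higher from compound 1 to compound 2 (within the scatter), concerns the group on the nitrogen and not the linker, so it does not bear on the present change. Compound 4 `Nc1ccccc1NC(=O)/C=C/c1ccc(Cn2cnc3c(Nc4cccc(OC(F)(F)F)c4)nc(Cl)nc32)cc1` differs from compound 3 by 2-((2-aminophenyl)carbamoyl)ethenyl in place of (2-aminophenyl)carbamoyl on an aromatic carbon. Compounds 1 and 2 both carry this ethenyl linker and both sit far below compound 3, so a decrease is expected, though their nitrogen substituent is not the same as in compound 4. Compound 4 is therefore expected to give 18%, in the range 5% to 40%, a step of a number 29.7 percentage points lower from compound 3 to compound 4 (beyond the scatter).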

Compound 4, a percentage reported as inhibition, at one concentration (the size of the read-out at that concentration, not a potency): 2.1%
For compound 4 the middle estimate is 15.9 percentage points above the measured one, outside the stated range (below it).
By their numbers in this assay, from the lowest: compounds 4, 1 and 2 (each within the scatter of the next); then compound 3.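

With the 3-(trifluoromethoxy)phenyl group held constant, the linker change alone gives a number 45.6 percentage points lower from compound 3 to compound 4 (beyond the scatter) in this assay, so the ethenyl extension at this position comes with a large loss of inhibition. Among the ethenyl compounds, the group on the nitrogen shows no effect beyond the scatter, with a number 6 percentage points lower from compound 2 to compound 4 (within the scatter) and a number 5 percentage points lower from compound 1 to compound 4 (within the scatter) both lying within it. No evidence is available that explains this result. Going by these compounds, it remains open whether an ethyl chain in place of the ethenyl unit would keep the inhibition of compound 3. Also open, on these data alone, is whether cyclohexyl or 3-chlorophenyl on the nitrogen would do so on the shorter linker.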